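Ester in Place of Trifluoromethyl: Expected Cytotoxicity

The source may report more compounds than this note shows. Statements on the series, on what has been measured and on what is new or still open speak of the compounds shown alone.

Compound 1 `O=C(/C=C/c1ccc2c(c1)B(O)OC2)c1ccc(Cl)c(Cl)c1`: in an ADME assay on L929 cells (Mus musculus) for cytotoxicity, read by resazurin assay, with a stated time of 72 h (a higher number here means a weaker inhibitor, a lower number a stronger inhibitor), compound 1 gives > 10 ug/mL, which is a limit of the assay rather than a number.
Compound 2 `O=C(/C=C/c1ccc2c(c1)B(O)OC2)c1ccc(C(F)(F)F)cc1`: in this assay compound 2 gives > 10 ug/mL, again a limit.
Compound 3 `O=C(CCc1ccc2c(c1)B(O)OC2)c1ccccc1`: in this assay compound 3 gives > 10 ug/mL, also a limit.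

Where does compound 2 stand? Its result in this assay is only a limit, and the two other values shown are limits too, so no ordering of the three compounds is possible; all sit together at the limit of > 10 ug/mL in this assay, at which 3 of the 3 values shown sit. The three share one core and differ only in a peripheral group or in the saturation of the linking chain, and none of these variations has moved the read-out off the limit.

Compound 4 `CCOC(=O)c1ccc(C(=O)/C=C/c2ccc3c(c2)B(O)OC3)cc1` has not yet been tested. It differs from compound 2 by ethoxycarbonyl in place of trifluoromethyl on an aromatic carbon. Within the data shown here, no measured step exists between compounds that differ in a single place, so the size of this step cannot be read from data. Given that every measured value sits at the limit of > 10 ug/mL in this assay, at which 3 of the 3 values shown sit, the expectation in this assay is for no shift beyond the scatter, and the step that the limit leaves unreadable from compound 2 to compound 4 is expected to be negligible. Compound 4 is therefore estimated at 15 ug/mL, with a range from 8 ug/mL to 40 ug/mL, and the assay will most probably once more report only a limit.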

Compound 4, half-maximal inhibitory concentration: > 10 ug/mL
Compound 4: a limit, no number; the forecaster's own chance of this, stated with the estimate: 80%; the middle value lies beyond the limit too.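

The step from compound 2 to compound 4, ethoxycarbonyl in place of trifluoromethyl, cannot be read, as both results in this assay are limits and not numbers. The compounds shown leave open at what concentration any of them harms these cells, and whether any of their structural differences alters it, for all four share one result: the limit of > 10 ug/mL in this assay, at which 4 of the 4 values shown sit.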